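The source may hold more compounds than are shown below. What is called first, only, known or untested is meant among the compounds shown, and "the series" means these compounds.

Measured so far:
Compound 1 `Cc1ccccc1OCc1ccccc1-c1nc(COc2ccc(Cl)cc2)cs1`: 65.1% in a functional assay on the whole organism (strain Wistar albino) for inhibition, with Rattus norvegicus as the target, read by paw edema, at a dose of 10 mg/kg by the oral route; on this read-out lower numbers stand for less inhibition and higher numbers for more inhibition at the one dose given (going by the name of the read-out)
Compound 2 `Cc1ccccc1OCc1ccccc1-c1nc(-c2cc(Cl)sc2S(N)(=O)=O)cs1`: 70.1% in this assay

Compound 1 stands lowest of the two numbers, though its gap to compound 2 is within the scatter. Compound 3 `Cc1cccc(OCc2ccccc2-c2nc(COc3ccc(Cl)cc3)cs2)c1` differs from compound 1 by 3-methylphenyl in place of 2-methylphenyl on an oxygen on a saturated carbon. Among the measured compounds shown here, the only measured step, a number 5 percentage points higher from compound 1 to compound 2 (within the scatter), alters a different part of the shared core and lay within the scatter, so it offers no guide to this change. For compound 3 no step beyond the scatter is expected, a number 1.1 percentage points lower from compound 1 to compound 3 (within the scatter). Compound 3 is estimated at 64%, between 50% and 78%.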

Compound 3, a percentage reported as inhibition, in the whole organism at one dose (the size of the read-out at that dose, not a potency): 67.7%
For compound 3 the middle estimate is 3.7 percentage points below the measured one; measured number inside the range.
By their numbers in this assay, from the lowest: compounds 1, 3 and 2 (each within the scatter of the next).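

Moving the methyl group, with 3-methylphenyl in place of 2-methylphenyl on an oxygen on a saturated carbon, gives a number 2.6 percentage points higher from compound 1 to compound 3 (within the scatter) in this assay. Among the compounds shown here, this is the first reading at this position, and at this one dose the two methyl placements cannot be told apart. No measurement shown here accounts for this result. Still open, as far as these compounds go, is whether a plain phenyl with no methyl, or a carboxylic acid or an amine in place of the methyl, would move the number beyond the scatter.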